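The source may report more compounds than this note shows. Statements on the series, on what has been measured and on what is new or still open speak of the compounds shown alone.

Going by the values given here, compound 2 `CN1CCN(c2ccc(C3=NN(C(=O)c4ccc(C(F)(F)F)cc4)C(c4ccc(N(C)C)cc4)C3)cc2)CC1` gives 84.1% in a functional assay on HCC1806 cells (Homo sapiens) for inhibition, read by sulforhodamine B assay, tested at 10 uM (on this read-out lower numbers stand for less inhibition and higher numbers for more inhibition at the one concentration tested (going by the name of the read-out)), the higher of the two numbers measured so far. Compound 1 `COC(=O)CC(=O)N1N=C(c2ccc(N3CCN(C)CC3)cc2)CC1c1ccc(N(C)C)cc1`, which carries a (methoxycarbonyl)methyl group on the carbonyl carbon instead, gives -8.3%, and the step of a number 92.4 percentage points higher from compound 1 to compound 2 (beyond the scatter) is the only one known. Compound 3 `CN1CCN(c2ccc(C3=NN(S(C)(=O)=O)C(c4ccc(N(C)C)cc4)C3)cc2)CC1` differs from compound 2 by methylsulfonyl in place of (4-(trifluoromethyl)phenyl)carbonyl on an amine nitrogen in a ring. That step bears on this change, since the group that went with the large rise from compound 1 to compound 2 is now taken away again. A large fall is therefore expected, a number 64.1 percentage points lower from compound 2 to compound 3 (beyond the scatter). Compound 3 is estimated at 20%, within -10% to 55%.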

Compound 3, a percentage reported as inhibition, at one concentration (the size of the read-out at that concentration, not a potency): -18.5%
Compound 3: the middle estimate sits 38.5 percentage points above what was measured, and the stated range ends above it.
By their numbers in this assay, from the lowest: compound 3; then compound 1; then compound 2.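

With methylsulfonyl on the amine nitrogen in the ring, this assay falls: a number 102.6 percentage points lower from compound 2 to compound 3 (beyond the scatter). Methylsulfonyl also differs from the ester-bearing carbonyl group of compound 1, a modest step, a number 10.2 percentage points lower from compound 1 to compound 3 (beyond the scatter). Among these three compounds, then, only compound 2, with (4-(trifluoromethyl)phenyl)carbonyl, gives a high number, and two quite different replacements both lose it, though no measurement at hand explains this. The compounds shown leave open whether the high number goes with the aromatic ring itself or with the trifluoromethyl on it. A plain benzoyl group at this nitrogen would separate the two.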